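The source may hold more compounds than are shown below. What is called first, only, known or untested is meant among the compounds shown, and "the series" means these compounds.

In a functional assay on B16 cells (Mus musculus) for cytotoxicity, read by MTT assay, with a stated time of 48 h (a lower number here means a stronger inhibitor, a higher number a weaker inhibitor), compound 1 (`C=C1CCC[C@]2(C)CCC(C=O)=CC[C@@]12C`) gives 230000 nM and compound 2 (`CC1(C)CCCC2=CC=C(C=O)CC[C@]21C`) gives 145000 nM in the same test. Among the compounds with values here, these two numbers lie within the usual scatter of each other, so compound 1 cannot be separated from the only other measured compound. Compound 3 (`C#CC1=CC[C@@]2(C)C(=C)CCC[C@]2(C)CC1`) keeps the core of compound 1 but has not yet been measured. It carries ethynyl in place of formyl on a double-bonded ring carbon of the seven-membered non-aromatic ring of carbon only (ethynyl in place of formyl on a double-bonded ring carbon). Within the data shown here, no pair of measured compounds differs in one place, so the data offer no direct guide to this replacement. The expectation therefore starts from compound 1 at 230000 nM and is that this assay will show no step beyond the scatter, with no firm direction. The estimated change is a 1.1-fold higher number from compound 1 to compound 3 (0.04 log units; within the scatter) and is expected to remain within the scatter. In this assay the expected value for compound 3 is 250000 nM with an estimated range from 100000 nM to 600000 nM for repeated measurements.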

Compound 3, half-maximal inhibitory concentration: 507000 nM
Beside the measured number, compound 3's estimate is 2.0-fold (0.31 log units) below it; the range from low to high includes it.
By their numbers in this assay, from the lowest: compounds 2 and 1 (each within the scatter of the next); then compound 3.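

In this assay, within the data shown here, the replacement of formyl by ethynyl on a double-bonded ring carbon of the seven-membered non-aromatic ring gives a 2.2-fold higher number from compound 1 to compound 3 (0.34 log units; beyond the scatter) as a modest step, and this is the first reading of any change at this position, since the earlier compounds offered no pair differing in one place. It shows that this position is not indifferent to the group it carries: with the rest of the core of compound 1 unchanged, ethynyl gives a weaker inhibitor than formyl, though only by a modest margin. Formyl counts as a hydrogen-bond acceptor and ethynyl does not, but no measurement here connects that difference with the step, and nothing available explains why the number rises.

On these data alone, a single replacement gives no trend, so it remains open whether a carboxylic acid, an amine or a hydroxymethyl group on the same ring carbon would lower the number or raise it further. Also open, as far as these compounds go, is whether ethynyl would have the same effect on the core of compound 2, where the ring double bonds lie differently.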